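The compounds below may be only part of what the source reports. "The series", "measured", "known", "first", "only" and "open" are said of these compounds alone.

Going by the values given here, compound 1 `CCN(CC)CCNC(=O)c1ccc(C(CC)(CC)c2ccc(OCCC(O)(CC)CC)c(C)c2)n1CC` is the only member of this small set for which an assay on cells for agonist activity at vitamin D3 receptor (Homo sapiens), with a stated time of 96 h (on this read-out higher numbers stand for an effect only at larger amounts of compound and lower numbers for an effect already at smaller amounts), returns a number: compound 1 gives 2.3 nM. Compound 2 `C=CCN(C)C(=O)c1ccc(C(CC)(CC)c2ccc(OCCC(O)(CC)CC)c(C)c2)n1CC` reaches only the limit of this assay, > 10000 nM. Compound 3 `CCn1c(C(=O)Nc2ccc(OC(F)(F)F)cc2)ccc1C(CC)(CC)c1ccc(OCCC(O)(CC)CC)c(C)c1` likewise stops at the limit, > 10000 nM. Compound 4 `CCn1c(C(=O)Nc2cccc(C(F)(F)F)c2)ccc1C(CC)(CC)c1ccc(OCCC(O)(CC)CC)c(C)c1` differs from compound 1 in one place: 3-(trifluoromethyl)phenyl in place of 2-(diethylamino)ethyl on an amide-type nitrogen. The closest measured step is an at least 4300-fold higher number from compound 1 to compound 3 (3.63 log units; beyond the scatter), which swaps the same chain for another aryl group; an at least 4300-fold higher number from compound 1 to compound 2 (3.63 log units; beyond the scatter) is also large, and both outcomes sit at the limit of > 10000 nM in this assay, at which 2 of the 3 values shown sit. The chemist therefore expects a large upward step in this assay for compound 4, a 6500-fold higher number from compound 1 to compound 4 (3.81 log units; beyond the scatter). Her estimate for compound 4 is 15000 nM, between 2000 nM and 100000 nM, with a real chance that only a limit is reported.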

Compound 4, half-maximal effective concentration: 5900 nM
Compound 4: middle estimate off by 2.5-fold (0.41 log units), on the high side; the measured number falls inside the stated range.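

Going by these compounds alone, putting 3-(trifluoromethyl)phenyl on this amide-type nitrogen gives the first full measure of what losing the 2-(diethylamino)ethyl chain costs in this assay, a 2600-fold higher number from compound 1 to compound 4 (3.41 log units; beyond the scatter), where the earlier steps gave only floors. The other two steps, an at least 1.6-fold lower number from compound 3 to compound 4 (0.22 log units; that floor lies within the scatter) and an at least 1.6-fold lower number from compound 2 to compound 4 (0.22 log units; that floor lies within the scatter), have floors within the scatter, so they set no order among these compounds.

On these data alone, the true size of those two steps stays open because of the limit: the limit of > 10000 nM in this assay, at which 2 of the 4 values shown sit. Also open is whether an aryl ring carrying a dimethylamino group, or a shorter 2-(dimethylamino)ethyl chain, on this nitrogen would keep a low number.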